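The source may report more compounds than this note shows. Statements on the series, on what has been measured and on what is new or still open speak of the compounds shown alone.

Of the compounds shown here, two sharing one core have been measured in an assay on membranes from HEK293 cells for displacement of a labelled ligand from adenosine receptor A2b (Homo sapiens), read by scintillation counting, with a stated time of 30 min, tested at 1 uM; a lower number here means less inhibition, a higher number more inhibition at the concentration tested (going by the name of the read-out). Compound 1 `CC1=C(C(=O)OCc2ccccc2)C(c2ccsc2)NC(=O)N1` gives 44% there, and compound 2 `COC(=O)C1=C(C)NC(=S)NC1c1ccoc1` gives 48%; the two numbers lie within the usual scatter of each other, so neither stands apart. Compound 3 `CC1=C(C(=O)OCc2ccccc2)C(c2ccoc2)NC(=S)N1` is not yet measured. It differs from compound 2 as phenyl in place of hydrogen on a saturated chain carbon bound to an oxygen next to a carbonyl group. Going by the values given here, no measured pair isolates this change, so nothing is known of its effect; since compound 1 carries the same benzyl group and shows 44%, the step expected in this assay is a number 2 percentage points lower from compound 2 to compound 3 (within the scatter), not beyond the scatter. Compound 3 is estimated at 46%, within 25% to 65%.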

Compound 3, a percentage reported as inhibition, at one concentration (the size of the read-out at that concentration, not a potency): 36%
Compound 3: the middle estimate sits 10 percentage points above what was measured; measured number inside the range.
By their numbers in this assay, from the lowest: compounds 3, 1 and 2 (each within the scatter of the next, the first and the last beyond it).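

In this assay, the change from methyl to benzyl now has a measured effect, with phenyl in place of hydrogen on a saturated chain carbon bound to an oxygen next to a carbonyl group giving a number 12 percentage points lower from compound 2 to compound 3 (beyond the scatter) on the shared core. This position therefore responds to the change, though only modestly. No measurement at hand accounts for the step. Going by these compounds, whether an ethyl group or a longer chain would fall between methyl and benzyl remains open, as does the effect of a carboxylic acid in place of the ester. On these data alone, it is also open whether the same change acts alike on the core of compound 1.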